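Adding fluoro to compound 2: what to expect

This account rests on a few compounds, and the source may have more. Where it says the series, first, only, none or still open, it means among the compounds named here.

- Compound 1 `CCO/N=C1/C(=O)N(Cc2cn(CC(=O)N3CCN(c4cc5c(cc4F)c(=O)c(C(=O)O)cn5C4CC4)CC3)nn2)c2ccc(C)cc21` gives 32 ug/mL
- Compound 2 `CCO/N=C1/C(=O)N(Cc2cn(CC(=O)N3CCN(c4cc5c(cc4F)c(=O)c(C(=O)O)cn5C4CC4)CC3)nn2)c2ccccc21` gives 64 ug/mL
- Compound 3 `CO/N=C1/C(=O)N(Cc2cn(CC(=O)N3CCN(c4cc5c(cc4F)c(=O)c(C(=O)O)cn5C4CC4)CC3)nn2)c2ccccc21` gives 128 ug/mL

In an ADME assay on Vero cells (Chlorocebus sabaeus) for cytotoxicity (on this read-out higher numbers stand for lower toxicity in this test and lower numbers for higher toxicity in this test), compound 2 gives 64 ug/mL and lies within the scatter of both compound 1 and compound 3. Compound 4 `CCO/N=C1/C(=O)N(Cc2cn(CC(=O)N3CCN(c4cc5c(cc4F)c(=O)c(C(=O)O)cn5C4CC4)CC3)nn2)c2ccc(F)cc21` differs from it by fluoro in place of hydrogen on an aromatic carbon. The nearest guide is a 2.0-fold higher number from compound 1 to compound 2 (0.30 log units; within the scatter) with hydrogen in place of methyl on an aromatic carbon. A change elsewhere, hydrogen in place of methyl on a saturated chain carbon, gave a 2.0-fold higher number from compound 2 to compound 3 (0.30 log units; within the scatter) in the same test. Going by the values given here, neither measured step goes beyond the scatter, though no measured compound carries fluoro. No larger effect is expected, and the estimated change is no change at the digits printed from compound 2 to compound 4 (within the scatter) at most within that scatter. Compound 4 is estimated at 64 ug/mL with an expected range from 32 ug/mL to 128 ug/mL in this read-out.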

Compound 4, half-maximal cytotoxic concentration: 8 ug/mL
The estimate for compound 4 lay 8.0-fold (0.90 log units) above the measured number; the whole stated range lies above it.
By their numbers in this assay, from the lowest: compound 4; then compounds 1, 2 and 3 (each within the scatter of the next, the first and the last beyond it).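

On this aromatic carbon, the size of the change depends on the group: in this assay fluoro in place of hydrogen gives an 8.0-fold lower number from compound 2 to compound 4 (0.90 log units; beyond the scatter), whereas the earlier step between methyl and hydrogen at this carbon stayed within the scatter. Fluoro in place of methyl gives a 4.0-fold lower number from compound 1 to compound 4 (0.60 log units; beyond the scatter), so fluoro also parts from methyl here. Nothing available explains this difference.

Chloro or an amine on this carbon would test whether the fall is specific to fluoro. As far as these compounds go, it also remains open whether fluoro has the same effect with the methoxy group of compound 3.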